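Oxazolidinone series: lipophilicity notes ahead of compound 4

The source may hold more compounds than are shown below. What is called first, only, known or untested is meant among the compounds shown, and "the series" means these compounds.

Values in a physicochemical assay for lipophilicity, read by HPLC (a higher number here means a more lipophilic compound, a lower number a more polar compound), for the three measured compounds:
- compound 1 `CC(=O)NC[C@H]1CN(c2ccc(OC[C@@H](O)CNc3cccnc3)c(F)c2)C(=O)O1` gives 0.02
- compound 2 `CC(=O)NC[C@H]1CN(c2ccc(OC[C@H](O)CNc3cccnc3)c(F)c2)C(=O)O1` gives -0.18
- compound 3 `CC(=O)NC[C@H]1CN(c2ccc(OC[C@@H](O)CNC3CC3)c(F)c2)C(=O)O1` gives 0.02

Compound 3 stands level with compound 1 at the digits printed, and together these two are the highest of the three numbers; its nearest neighbour is compound 1 and its furthest is compound 2. The steps of no change at the digits printed from compound 1 to compound 3 (within the scatter) and a number 0.20 log units higher from compound 2 to compound 3 (within the scatter) both lie within the scatter, so the swap of pyridin-3-yl for cyclopropyl on the amine nitrogen leaves this assay unmoved. The step of a number 0.20 log units lower from compound 1 to compound 2 (within the scatter) is likewise within the scatter, which fits (the fact that compounds 1 and 2 differ only in the configuration as drawn).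

Compound 4 `CC(=O)NC[C@H]1CN(c2ccc(OC[C@@H]3CNC(=O)O3)c(F)c2)C(=O)O1` is not yet measured. Its difference from compound 3 is 2-oxo-1,3-oxazolidin-5-yl in place of 2-(cyclopropylamino)-1-hydroxyethyl on a saturated chain carbon bound to an oxygen on an aromatic ring; cut one bond further out it reads 3-(cyclopropylamino)-2-hydroxypropoxy to (2-oxo-1,3-oxazolidin-5-yl)methoxy. Within the data shown here, no measured step covers this change: the steps from compound 1 and compound 2 to compound 3 only exchange the group on the amine nitrogen and were within the scatter, and none removes the amine and hydroxyl in favour of a cyclic carbamate. On that basis no step beyond the scatter is expected, and the expected step is a number 0.13 log units higher from compound 3 to compound 4 (within the scatter). Compound 4 is estimated at 0.15, within -0.45 to 0.75.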

Compound 4, partition coefficient: 0.01
For compound 4 the middle estimate is 0.14 log units above the measured one; the range from low to high includes it.
By their numbers in this assay, from the lowest: compounds 2, 4, 1 and 3 (each within the scatter of the next).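

In this assay, among these compounds, 2-oxo-1,3-oxazolidin-5-yl in place of 2-(cyclopropylamino)-1-hydroxyethyl on a saturated chain carbon bound to an oxygen on an aromatic ring gives a number 0.01 log units lower from compound 3 to compound 4 (within the scatter) and is the only change here that closes the open side chain into a ring. Set against the pyridin-3-yl side chains, the same entering group gives a number 0.01 log units lower from compound 1 to compound 4 (within the scatter) and a number 0.19 log units higher from compound 2 to compound 4 (within the scatter) so that all three steps lie within the scatter, and at this place this assay does not separate the ring from any of the three open side chains shown. The one available note on these compounds concerns the configuration of compounds 1 and 2 and does not bear on this result.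

Still open, on these data alone, is whether a group of another kind at this place, such as a carboxylic acid or a longer chain ending in a primary amine, would give a step beyond the scatter in this assay. Also open, as far as these compounds go, is how the mirror-drawn stereocentre of the 2-oxo-1,3-oxazolidin-5-yl ring would read there.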